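The compounds below may be only part of what the source reports. "The series", "measured", "known", "first", "only" and "open" are said of these compounds alone.

Working notes on the series in a functional assay on K-562R cells (Homo sapiens) for cytotoxicity, read by XTT assay, with a stated time of 24 h; a higher number here means a weaker inhibitor, a lower number a stronger inhibitor. Compound 1 (`Cc1ccc(OCCCCn2ccnc2)c(C(=O)Nc2ccc(C)c(Nc3nccc(-c4cccnc4)n3)c2)c1`) gives 48600 nM. Compound 2 (`Cc1ccc(NC(=O)c2ccc(OCCCCn3ccnc3)cc2)cc1Nc1nccc(-c2cccnc2)n1`) gives 99400 nM, the higher of the two numbers and so the weaker inhibitor of the pair, and its gap to compound 1 lies beyond the usual scatter.

The next entry is compound 3 (`Cc1ccc(NC(=O)c2ccc(OCCCCn3ccnc3)c(I)c2)cc1Nc1nccc(-c2cccnc2)n1`), which carries iodo in place of hydrogen on an aromatic carbon, ortho to a 4-(1H-imidazol-1-yl)butoxy group and meta to a large group: iodo in place of hydrogen on an aromatic carbon. Among the compounds with values here, no measured pair differs in one place only, so this change has no direct precedent, and the expectation is loosely founded. With compound 2 at 99400 nM and compound 1 at 48600 nM, the only anchors are two high numbers. A modest move toward a lower number is expected, although a result within the scatter of compound 2 would not be surprising. The estimated change is a 1.8-fold lower number from compound 2 to compound 3 (0.26 log units; within the scatter). In this assay, compound 3 is estimated at 55000 nM, with an expected range of 18000 nM to 130000 nM.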

Compound 3, half-maximal inhibitory concentration: 52400 nM
The estimate for compound 3 lay 1.0-fold (0.02 log units) above the measured number; low and high end bracket the measured number.
By their numbers in this assay, from the lowest: compounds 1, 3 and 2 (each within the scatter of the next, the first and the last beyond it).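

In this assay, within the data shown here, the step of a 1.9-fold lower number from compound 2 to compound 3 (0.28 log units; within the scatter) is the first between compounds that differ in one place, and it concerns iodo in place of hydrogen on an aromatic carbon, ortho to a 4-(1H-imidazol-1-yl)butoxy group and meta to a large group. Among these compounds, this position therefore accepts one iodine atom without a shift that can be told from the scatter, so compound 2 and compound 3 cannot be ranked against each other, and the single step gives no sign that iodo here moves the number in a real way. Nothing measured bears on the reason for this result.

The compounds shown leave open whether a smaller halogen such as fluoro or chloro, or a group of another kind such as methoxy or an amine, would give a step beyond the scatter at this same carbon. They also leave open whether iodo would give a readable step on the arrangement of compound 1, or whether a shorter or longer chain in place of the 4-(1H-imidazol-1-yl)butoxy group would change the reading of this position.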